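Adding a but-3-en-1-yl chain to compound 1

A few compounds are considered here, and "the series" means these few. Any claim that something is new, unique, unknown or untested is made for them only; others in the source may bear on it.

- compound 1 `O=C1C=CC2(C=C1)OCCC(=O)N2c1ccccc1` gives 1300 nM
- compound 2 `C=C(C)CC1COC2(C=CC(=O)C=C2)N(c2ccccc2)C1=O` gives 450 nM

Within the data shown here, in a functional assay on BV-2 cells (Mus musculus), read by Griess assay, with a stated time of 24 h (a lower number here means a stronger inhibitor, a higher number a weaker inhibitor), compound 1 holds the higher of the two numbers so far (1300 nM) and is the weaker inhibitor of the pair. Compound 3 `C=CCCC1COC2(C=CC(=O)C=C2)N(c2ccccc2)C1=O` has not yet been measured. It differs from compound 1 in one place: but-3-en-1-yl in place of hydrogen on a saturated ring carbon with but-3-en-1-yl in place of hydrogen on a saturated ring carbon.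

Among the measured compounds shown here, one measured step bears on this change. Compound 2 carries 2-methylprop-2-en-1-yl in place of that same hydrogen, and the step is a 2.9-fold lower number from compound 1 to compound 2 (0.46 log units; beyond the scatter) as a modest move beyond the scatter. A step of similar size in the same direction, towards a lower number, is therefore expected for the but-3-en-1-yl chain in this assay as well. This expectation rests on a single pair, and nothing measured yet separates one such chain from the other.

The expected change by this estimate is a 2.6-fold lower number from compound 1 to compound 3 (0.41 log units; beyond the scatter) and remains unconfirmed. In this assay compound 3 is estimated at 500 nM (expected range 200 nM to 1200 nM).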

Compound 3, half-maximal inhibitory concentration: 730 nM
Compound 3: middle estimate off by 1.5-fold (0.16 log units), on the low side; measured number inside the range.
By their numbers in this assay, from the lowest: compounds 2, 3 and 1 (each within the scatter of the next, the first and the last beyond it).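

At the saturated ring carbon, the but-3-en-1-yl chain gives a 1.8-fold lower number from compound 1 to compound 3 (0.25 log units; within the scatter) in this assay and so cannot be told from the hydrogen of compound 1, although a 2.9-fold lower number from compound 1 to compound 2 (0.46 log units; beyond the scatter) stands beyond the scatter for the 2-methylprop-2-en-1-yl chain. Exchanging one chain for the other gives a 1.6-fold higher number from compound 2 to compound 3 (0.21 log units; within the scatter) and so does not separate the two chains either: compound 3 sits within the scatter of both neighbours, and the three numbers do not yet form a clean ranking at this carbon. No supporting data are available to account for these numbers.

Still open, from the compounds shown here alone, is whether a saturated butyl chain, without the double bond, would behave like either of these two chains in this assay at this ring carbon. Also open, going by these compounds, is whether a longer chain, or a chain ending in an amine or a carboxylic acid, would move the number clearly beyond the scatter from compound 1 in either direction.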